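The source may hold more compounds than are shown below. What is called first, only, known or untested is meant among the compounds shown, and "the series" means these compounds.

Compound 3 `CCCC[S+]([O-])c1nc(N)c2nc(O)n(Cc3ccccc3)c2n1` gives 1 mg/kg in a functional assay on the whole organism for activation, with Mus musculus as the target (on this read-out lower numbers stand for an effect already at smaller amounts and higher numbers for an effect only at larger amounts of compound), and so stands lowest of the three numbers: compound 1 `CCc1nc(N)c2nc(O)n(Cc3ccccc3)c2n1` gives 3 mg/kg and compound 2 `Nc1ncnc2c1nc(O)n2Cc1ccc(F)cc1` gives 30 mg/kg. Compound 4 `COc1nc(N)c2nc(O)n(Cc3ccccc3)c2n1` differs from compound 3 in one place: a group of 2 heavy atoms (1 carbon, 1 oxygen; no ring) in place of a group of 6 heavy atoms (4 carbon, 1 oxygen, 1 sulfur; no ring), on an aromatic carbon. Going by the values given here, the only measured step at the same carbon runs the other way, a 3.0-fold lower number from compound 1 to compound 3 (0.48 log units; beyond the scatter), where a group of 2 heavy atoms gave way to the group of 6 heavy atoms. Putting methoxy, again a group of 2 heavy atoms, in place of that group is expected to undo much of that gain, so a step upward in this assay is expected, a 3.0-fold higher number from compound 3 to compound 4 (0.48 log units; beyond the scatter). Compound 4 is therefore estimated at 3 mg/kg, with a range from 1 mg/kg to 10 mg/kg.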

Compound 4, minimum effective dose: > 1 mg/kg
Compound 4: only a limit was reported; the forecaster's own chance of this, stated with the estimate: 5%; the middle value does not contradict the limit.
By their numbers in this assay, from the lowest: compound 3; then compound 1; then compound 2.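

Compound 4 is reported only as a limit: the limit of > 1 mg/kg in this assay, at which 1 of the 4 values shown sits. On the aromatic carbon between two ring nitrogen atoms, methoxy in place of the group of 6 heavy atoms gives a number no lower from compound 3 to compound 4 (the limit leaves the size open), so this change shows no gain over compound 3 in this assay. The size of that step and the step between the compounds carrying ethyl and methoxy cannot be read.

Still open, as far as these compounds go, is how methoxy ranks against ethyl at this carbon. Also open, from the compounds shown here alone, is whether a butoxy chain or an amine there would match the group of 6 heavy atoms.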